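Replacing furan-2-yl with 2-phenoxyethyl in compound 3

The source may report more compounds than this note shows. Statements on the series, on what has been measured and on what is new or still open speak of the compounds shown alone.

In an ADME assay on HepG2 2.2.15 cells (Homo sapiens) for cytotoxicity (on this read-out lower numbers stand for higher toxicity in this test and higher numbers for lower toxicity in this test), compound 1 (`CC(=O)OCCc1c(-c2ccccc2Cl)c2cc(Cl)ccc2[nH]c1=O`), with a methyl on its carbonyl carbon, gives 27000 nM. Compound 2 (`O=C(OCCc1c(-c2ccccc2Cl)c2cc(Cl)ccc2[nH]c1=O)c1cccs1`), with thiophen-2-yl there, returns only a limit of the assay, > 1700000 nM. Compound 3 (`O=C(OCCc1c(-c2ccccc2Cl)c2cc(Cl)ccc2[nH]c1=O)c1ccco1`), with furan-2-yl, gives 98000 nM, the higher of the two actual numbers. The measured steps are a 3.6-fold higher number from compound 1 to compound 3 (0.56 log units; beyond the scatter), an at least 62-fold higher number from compound 1 to compound 2 (1.79 log units; beyond the scatter) and an at least 17-fold lower number from compound 2 to compound 3 (1.23 log units; beyond the scatter).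

Compound 4 (`O=C(CCOc1ccccc1)OCCc1c(-c2ccccc2Cl)c2cc(Cl)ccc2[nH]c1=O`) has 2-phenoxyethyl in place of furan-2-yl on a carbonyl carbon. All three measured steps change the same spot, but none involves this group. They range from modest to large, and the two ring-bearing groups lie far apart, which leaves the direction open. The best expectation is therefore no change beyond the scatter, with wide uncertainty. The expected step is a 1.2-fold lower number from compound 3 to compound 4 (0.09 log units; within the scatter). For compound 4 the estimated value is 80000 nM, with an expected range from 20000 nM to 400000 nM.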

Compound 4, half-maximal cytotoxic concentration: 46000 nM
Estimate against measurement, compound 4: 1.7-fold (0.24 log units) above; low and high end bracket the measured number.
By their numbers in this assay, from the lowest: compounds 1 and 4 (each within the scatter of the next); then compound 3. At a limit, above all of these: compound 2.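

In this assay, the change gives a 2.1-fold lower number from compound 3 to compound 4 (0.33 log units; beyond the scatter) and, against the small methyl group, a 1.7-fold higher number from compound 1 to compound 4 (0.23 log units; within the scatter) with no shift beyond the scatter, so a ring-bearing group on this carbonyl carbon does not by itself raise the number. The step of an at least 36-fold lower number from compound 2 to compound 4 (1.56 log units; beyond the scatter) also shows that a second ring-bearing group stays far from thiophen-2-yl, which now stands apart from the other three groups. The value of compound 2 is a limit of the assay and not a number, so that step gives only a minimum size: the limit of > 1700000 nM in this assay, at which 1 of the 4 values shown sits.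

The compounds shown do not separate the ring itself from the chain that carries it, and a phenyl group or a 2-(thiophen-2-yl)ethyl group on this carbonyl carbon would test that directly. From the compounds shown here alone, how an amine on this chain would read in this assay also remains open.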